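From Thiazole Amide to Pyridine Amide on a Shared Core

The compounds below may be only part of what the source reports. "The series", "measured", "known", "first", "only" and "open" are said of these compounds alone.

Compound 1 `CCC[C@@H](NC(=O)c1nccs1)c1cnc(Nc2ccc(C)nc2)c(Cl)c1` was tested in a functional assay on HEK293 cells for negative allosteric modulation of metabotropic glutamate receptor 5 (Homo sapiens), read by HTRF and inositol phosphate accumulation (on this read-out higher numbers stand for weaker inhibition and lower numbers for stronger inhibition), where compound 1 gives 8.2 nM. Among the three measured compounds this number stands second highest: compound 3 `C=CC[C@@H](NC(=O)c1nccs1)c1cnc(Nc2ccc(C)nc2)c(Cl)c1` gives 2.4 nM, while compound 2 `CCCC[C@@H](NC(=O)c1nccs1)c1cnc(Nc2ccc(C)nc2)c(Cl)c1` gives 30.9 nM. Every measured step changes only the chain on the saturated carbon: a 3.8-fold higher number from compound 1 to compound 2 (0.58 log units; beyond the scatter), a 3.4-fold lower number from compound 1 to compound 3 (0.53 log units; beyond the scatter) and a 13-fold lower number from compound 2 to compound 3 (1.11 log units; beyond the scatter).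

Compound 4 `CCC[C@@H](NC(=O)c1ccccn1)c1cnc(Nc2ccc(C)nc2)c(Cl)c1` differs from compound 1 at a different place: pyridin-2-yl in place of 1,3-thiazol-2-yl on a carbonyl carbon. None of the three measured steps touches the group on the carbonyl carbon, so none of them bears directly on this change; in all three measured compounds that group was the same. The measured steps show only that the chain on the saturated carbon moves the number by modest to large amounts, which says nothing about the amide heteroaryl. Among the measured compounds shown here, with no measured step on this change, the expectation rests on the value of compound 1 alone, and the expected step in this assay is none beyond the scatter, in either direction. Compound 4 is therefore estimated at 10 nM, within a range from 3 nM to 35 nM, which means an expected 1.2-fold higher number from compound 1 to compound 4 (0.09 log units; within the scatter).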

Compound 4, half-maximal inhibitory concentration: 27.8 nM
Compound 4: middle estimate off by 2.8-fold (0.44 log units), on the low side; low and high end bracket the measured number.
By their numbers in this assay, from the lowest: compound 3; then compound 1; then compounds 4 and 2 (each within the scatter of the next).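

In this assay the group on the carbonyl carbon proves able to move the number: pyridin-2-yl in place of 1,3-thiazol-2-yl gives a 3.4-fold higher number from compound 1 to compound 4 (0.53 log units; beyond the scatter) and so weakens inhibition, at a place that all three earlier compounds held constant. The size of this step matches that of a 3.4-fold lower number from compound 1 to compound 3 (0.53 log units; beyond the scatter) but runs the opposite way, so in this series a change on the carbonyl carbon can count for as much as the vinyl change on the chain. Nothing measured here explains the step, and this single pair cannot separate the differences between the two rings, which include ring size and the sulfur atom.

The compounds shown leave open how 1,3-oxazol-2-yl, pyrimidin-2-yl or a plain phenyl on the carbonyl carbon would compare with these two rings. Among the compounds shown here, they also leave open whether pyridin-2-yl would bring a step of similar size on the chain of compound 3, which carries the lowest number so far.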